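Compound 4 in the growth assay: an expectation from three limits

This account rests on a few compounds, and the source may have more. Where it says the series, first, only, none or still open, it means among the compounds named here.

Measured compounds:
compound 1 `O=C(O)CCc1ccncc1-c1ccc2ccccc2c1` — > 10000 nM
compound 2 `O=C(CCc1ccncc1-c1ccc2ccccc2c1)N1CCOCC1` — > 10000 nM
compound 3 `O=C(/C=C/c1ccncc1-c1ccc2cc[nH]c2c1)N1CCOCC1` — > 10000 nM

In a functional assay on A549 cells (Homo sapiens) for inhibition, read by sulforhodamine B assay, with a stated time of 72 h (on this read-out lower numbers stand for stronger inhibition of growth and higher numbers for weaker inhibition of growth), compound 1 reaches only a limit of the assay, > 10000 nM. Compound 2 likewise gives only a limit, > 10000 nM. Compound 3 also stops at a limit, > 10000 nM. Among the compounds with values here, the single measured step, a step that the two limits leave unreadable from compound 1 to compound 2, cannot be read because of the limit of > 10000 nM in this assay, at which 3 of the 3 values shown sit. Compound 1 therefore stands nowhere on a scale of numbers; it is known only to be weaker than the assay can report.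

Compound 4 `O=C(O)/C=C/c1ccncc1-c1ccc2ccccc2c1` differs from compound 1 by 2-carboxyethenyl in place of 2-carboxyethyl on an aromatic carbon. Within the data shown here, no measured step covers this kind of change. Compound 3 carries the same second double bond outside the aromatic rings and also sits at the limit, but it is not a one-place neighbour of compound 4 and its value shows no more than that. With every shown value at the limit, no step beyond the scatter can be expected in this assay in either direction. Compound 4 is expected to give about 15000 nM, within 5000 nM to 50000 nM. The expected step that the limit leaves unreadable from compound 1 to compound 4 is thus estimated to remain unreadable, with compound 4 most probably reported as a limit too.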

Compound 4, concentration for 50% growth inhibition: > 10000 nM
Compound 4: only a limit was reported; the forecaster's own chance of this, stated with the estimate: 85%; the middle value is on the limit's open side.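

No step can be read between compound 1 and compound 4 in this assay because both compounds give only a limit: the limit of > 10000 nM in this assay, at which 4 of the 4 values shown sit.

The compounds shown leave open which change to the shared core, if any, gives a growth inhibition value that can be read as a number.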